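Swapping chloro for methyl on the urea aryl group

A few compounds are considered here, and "the series" means these few. Any claim that something is new, unique, unknown or untested is made for them only; others in the source may bear on it.

The compounds share one core, a chain bearing two fluorophenyl groups and ending in a urea, and differ only in the aryl group on the urea nitrogen. Compound 1 `O=C(NCCCCC(c1ccc(F)cc1)c1ccc(F)cc1)Nc1ccc(Cl)cc1` carries a 4-chlorophenyl there; in a functional assay on MDA-MB-231 cells (Homo sapiens) for cytotoxicity, read by MTT assay, with a stated time of 48 h (on this read-out higher numbers stand for weaker inhibition and lower numbers for stronger inhibition), compound 1 gives 7680 nM. Compound 3 `O=C(NCCCCC(c1ccc(F)cc1)c1ccc(F)cc1)Nc1cccc(Cl)c1` carries a 3-chlorophenyl, and in this assay compound 3 gives 5070 nM; the step of a 1.5-fold lower number from compound 1 to compound 3 (0.18 log units; within the scatter) stays within the scatter, so these two numbers cannot be told apart. Compound 2 `CC(=O)Nc1ccc(NC(=O)NCCCCC(c2ccc(F)cc2)c2ccc(F)cc2)cc1` carries a 4-acetamidophenyl. In this assay compound 2 reaches only a limit, > 20000 nM. The step of an at least 2.6-fold higher number from compound 1 to compound 2 (0.41 log units; beyond the scatter) is read against (the limit of > 20000 nM in this assay, at which 1 of the 3 values shown sits).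

Compound 4 `Cc1cccc(NC(=O)NCCCCC(c2ccc(F)cc2)c2ccc(F)cc2)c1` is the next step from compound 1: 3-methylphenyl in place of 4-chlorophenyl on an amide-type nitrogen. Among the compounds with values here, two measured steps bear on it. The step of a 1.5-fold lower number from compound 1 to compound 3 (0.18 log units; within the scatter) shows that 3-chlorophenyl in place of 4-chlorophenyl changed nothing beyond the scatter. The step of an at least 2.6-fold higher number from compound 1 to compound 2 (0.41 log units; beyond the scatter) shows that acetamido in place of chloro weakened inhibition, but a methyl is not an acetamido, so that step offers little guidance. For compound 4 a number close to that of compound 1 is expected, 8000 nM, with a range from 3000 nM to 20000 nM. The expected step of a 1.0-fold higher number from compound 1 to compound 4 (0.02 log units; within the scatter) is thus estimated to stay within the scatter.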

Compound 4, half-maximal inhibitory concentration: > 20000 nM
Compound 4: no number, only a limit; the forecaster's own chance of this, stated with the estimate: 20%; middle value at least 2.5-fold (0.39 log units) away from the limit.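

Moving the chloro changed nothing beyond the scatter, yet methyl in place of chloro on an aromatic carbon gives an at least 3.9-fold higher number from compound 3 to compound 4 (0.59 log units; beyond the scatter) in this assay. The same holds against the other chloro compound, with an at least 2.6-fold higher number from compound 1 to compound 4 (0.41 log units; beyond the scatter), so the two chlorophenyl compounds are the only ones shown here that give a number rather than a limit. These two steps give only a minimum size, and the step from compound 2 to compound 4 cannot be read, because both compounds stop at a limit: the limit of > 20000 nM in this assay, at which 2 of the 4 values shown sit.

Going by these compounds, how much weaker compound 4 really is remains open. So does whether the number depends on chlorine itself, which a 3-bromophenyl, a 3-fluorophenyl or a 3-trifluoromethylphenyl on the urea nitrogen could test, along with a 4-methylphenyl for the position of the methyl.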